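Moving the methyl: compound 2 to compound 4

The source may hold more compounds than are shown below. What is called first, only, known or untested is meant among the compounds shown, and "the series" means these compounds.

In an ADME assay on MT4 cells (Homo sapiens) for cytotoxicity, read by MTT assay, with a stated time of 96 h (on this read-out higher numbers stand for lower toxicity in this test and lower numbers for higher toxicity in this test), compound 1 `NS(=O)(=O)c1ccc(N2N=C(c3ccccc3)CC2c2ccccc2F)cc1` gives 42000 nM and compound 3 `Cc1cccc(C2CC(c3ccc(Oc4ccccc4)cc3)=NN2c2ccc(S(N)(=O)=O)cc2)c1` gives 35000 nM. Compound 2 `Cc1ccccc1C1CC(c2ccc(OCc3ccccc3)cc2)=NN1c1ccc(S(N)(=O)=O)cc1` gives >= 100000 nM, which is a limit of the assay and not a number. Compound 2 therefore sits at the limit of >= 100000 nM in this assay, at which 1 of the 3 values shown sits.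

Compound 4 `Cc1ccc(C2CC(c3ccc(OCc4ccccc4)cc3)=NN2c2ccc(S(N)(=O)=O)cc2)cc1` carries 4-methylphenyl in place of 2-methylphenyl on a saturated ring carbon. Going by the values given here, no measured pair isolates this change. The expected step of an at least 1.5-fold lower number from compound 2 to compound 4 (0.18 log units; that floor lies within the scatter) is a modest one towards lower numbers in this assay. Among the compounds with values here, that expectation leans on compound 1 at 42000 nM and compound 3 at 35000 nM, the only true numbers available. Compound 4 is estimated at 65000 nM, with an expected range of 30000 nM to 100000 nM.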

Compound 4, half-maximal cytotoxic concentration: 35000 nM
For compound 4 the middle estimate is 1.9-fold (0.27 log units) above the measured one; the measured number falls inside the stated range.
By their numbers in this assay, from the lowest: compounds 3, 4 and 1 (each within the scatter of the next). At a limit, above all of these: compound 2.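

In this assay, going by these compounds alone, compounds 2 and 4 form the only pair here that differs in one place, and the move of the methyl gives an at least 2.8-fold lower number from compound 2 to compound 4 (0.45 log units; beyond the scatter). The placement of the methyl on this phenyl group, on the saturated ring carbon, therefore registers in the read-out beyond the scatter, with the same atoms in both compounds. Compound 2 remains a limit of the assay, so the step has only a floor: the limit of >= 100000 nM in this assay, at which 1 of the 4 values shown sits.

Still open, from the compounds shown here alone, is how an amine or a carboxylic acid in place of the methyl would read in this assay.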